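A few compounds are considered here, and "the series" means these few. Any claim that something is new, unique, unknown or untested is made for them only; others in the source may bear on it.

Working notes on the series.

Three close analogues have been measured in an assay on isolated protein for inhibition of Dihydrofolate reductase (Homo sapiens), read by spectrophotometry, using NADPH, with stated times of 5 s and 6 min, tested at 5 uM; a lower number here means a weaker effect, a higher number a stronger effect of the compound at the concentration tested. Compound 1 `CC(C)(C)c1ccc(OCCCON2C(N)=NC(N)=NC23CCSCC3)cc1` gives 85.3% in this assay. Compound 2 `NC1=NC2(CCSCC2)N(OCCCOc2cccc(Cl)c2)C(N)=N1` gives 88.3% in this assay. Compound 3 `NC1=NC2(CCSCC2)N(OCCCOc2ccccc2Cl)C(N)=N1` gives 86.3% in this assay. Among the compounds with values here, of these three numbers the one for compound 3 is the second highest; the nearest to it belongs to compound 1 and the furthest to compound 2, and both gaps lie within the usual scatter.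

Within the data shown here, only one single-point step is available within the set: a number 2 percentage points lower from compound 2 to compound 3 (within the scatter). Moving the chlorine round the aromatic ring therefore produced no change beyond the scatter, and all three compounds sit in the same narrow band of inhibition at this concentration.

Compound 4 `NC1=NC2(CCSCC2)N(OCCCOc2ccc(Cl)cc2)C(N)=N1` is the next member to be measured in this assay. Relative to compound 3 the change is 4-chlorophenyl in place of 2-chlorophenyl on an oxygen on a saturated carbon. Among the measured compounds shown here, the one step that bears on this, from compound 2 to compound 3, was within the scatter, so a further repositioning of the same chlorine is expected to give a step of a number 0.3 percentage points lower from compound 3 to compound 4 (within the scatter) that is likewise not beyond the scatter. Compound 4 is therefore estimated at 86% in this assay, with a range from 76% to 94%.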

Compound 4, a percentage reported as inhibition, at one concentration (the size of the read-out at that concentration, not a potency): > 90%
Compound 4: only a limit was reported; the forecaster's own chance of this, stated with the estimate: 0%; middle value at least 4 percentage points from the limit.
By their numbers in this assay, from the lowest: compounds 1, 3 and 2 (each within the scatter of the next). At a limit, above all of these: compound 4.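

Compound 4 is reported only as a limit, > 90% in this assay, and it is the only compound shown at that limit: the limit of > 90% in this assay, at which 1 of the 4 values shown sits.

For the group on an oxygen on a saturated carbon, the change to 4-chlorophenyl gives a number at least 3.7 percentage points higher from compound 3 to compound 4 (that floor lies within the scatter) and a number at least 1.7 percentage points higher from compound 2 to compound 4 (that floor lies within the scatter), so the earlier finding of no difference between 2-chlorophenyl and 3-chlorophenyl does not yet extend to 4-chlorophenyl, although neither floor establishes a gain beyond the scatter. Within the data shown here, the same compound also gives the first direct comparison of two groups at one place on an aromatic carbon, chloro in place of tert-butyl, as a number at least 4.7 percentage points higher from compound 1 to compound 4 (that floor lies within the scatter), and this floor likewise leaves the two groups unseparated.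

From the compounds shown here alone, how far compound 4 lies past the limit remains unknown, so whether any of these three steps exceeds the scatter cannot be read from this single-concentration result. Also open, going by these compounds, is what an amine or a carboxylic acid would give on the aromatic carbon that carries chloro in compound 4, and what a longer chain linking the aromatic ring to the shared core would give.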